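Phenyl carbamates of the selenocyanate series: cytotoxicity notes

This account rests on a few compounds, and the source may have more. Where it says the series, first, only, none or still open, it means among the compounds named here.

Measured so far:
compound 1, `C=CCOC(=O)Nc1ccc([Se]C#N)cc1`: 9800 nM
compound 2, `N#C[Se]c1ccc(NC(=O)Oc2ccc(F)cc2)cc1`: 29500 nM
compound 3, `Cc1ccc(OC(=O)Nc2ccc([Se]C#N)cc2)cc1`: 8700 nM

Within an ADME assay on 184B5 cells (Homo sapiens) for cytotoxicity, read by MTT assay, with a stated time of 72 h (a lower number here means a stronger inhibitor of growth, a higher number a weaker inhibitor of growth), compound 3 gives the lowest number of the three. Its nearest neighbour is compound 1, whose value lies within the scatter of that of compound 3, so no order between the two can be claimed. Within the data shown here, its furthest neighbour is compound 2, and the one measured step in this group runs a 3.4-fold lower number from compound 2 to compound 3 (0.53 log units; beyond the scatter).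

Compound 4, `N#C[Se]c1ccc(NC(=O)Oc2ccccc2)cc1`, differs from compound 3 in one place: hydrogen in place of methyl on an aromatic carbon. Among the measured compounds shown here, the only step that bears on this position is the fluoro-to-methyl change, which moved the number beyond the scatter. The present change removes the methyl without putting fluoro back, so a step no larger than that one, and possibly none beyond the scatter, is expected; the direction is guessed as a modest rise, a 1.4-fold higher number from compound 3 to compound 4 (0.14 log units; within the scatter).

Compound 4 is therefore estimated at 12000 nM, in the range 5500 nM to 26000 nM.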

Compound 4, concentration for total growth inhibition: 22700 nM
Estimate against measurement, compound 4: 1.9-fold (0.28 log units) below; the measured number falls inside the stated range.
By their numbers in this assay, from the lowest: compounds 3 and 1 (each within the scatter of the next); then compounds 4 and 2 (each within the scatter of the next).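

In this assay hydrogen in place of methyl gives a 2.6-fold higher number from compound 3 to compound 4 (0.42 log units; beyond the scatter). Hydrogen in place of fluoro gives a 1.3-fold lower number from compound 2 to compound 4 (0.11 log units; within the scatter), which leaves the two unseparated here, and of the three groups at this place only methyl stands apart. Phenyl in place of allyl on an oxygen next to a carbonyl group gives a 2.3-fold higher number from compound 1 to compound 4 (0.36 log units; beyond the scatter), the first step read at that oxygen.

No measurement at hand speaks to the reason for any of these steps. Open, as far as these compounds go, is whether an ethyl, a methoxy or an amine on the same aromatic carbon would go with methyl or stay with hydrogen and fluoro.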